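From a Racemic Amide to a Single Enantiomer

This account rests on a few compounds, and the source may have more. Where it says the series, first, only, none or still open, it means among the compounds named here.

Of the compounds shown here, three that share the same core have been measured. Compound 1 `CC(C(=O)NCc1ccc(C(F)(F)F)nc1NCc1ccc(Cl)cc1)c1ccc(NS(C)(=O)=O)c(F)c1` is the weakest of them: in a functional assay on CHO-K1 cells for antagonist activity at transient receptor potential cation channel subfamily V member 1 (Homo sapiens), read by FLIPR (a higher number here means a weaker inhibitor, a lower number a stronger inhibitor), compound 1 gives 65.7 nM. Exchanging its (4-chlorobenzyl)amino group for other amines gives compound 2 `CCCN(CCC)c1nc(C(F)(F)F)ccc1CNC(=O)C(C)c1ccc(NS(C)(=O)=O)c(F)c1` and compound 3 `CC(C(=O)NCc1ccc(C(F)(F)F)nc1N1CCC(c2ccccc2)CC1)c1ccc(NS(C)(=O)=O)c(F)c1`. In this assay compound 2 gives 0.2 nM, and compound 3 gives 0.6 nM. The two exchanges were large steps, a 330-fold lower number from compound 1 to compound 2 (2.52 log units; beyond the scatter) and a 110-fold lower number from compound 1 to compound 3 (2.04 log units; beyond the scatter), whereas between the two strong compounds the difference is modest, a 3.0-fold higher number from compound 2 to compound 3 (0.48 log units; beyond the scatter). Compound 3 therefore stands second of the three numbers, far from compound 1 and only modestly behind compound 2.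

Among the compounds with values here, compound 4 `C[C@@H](C(=O)NCc1ccc(C(F)(F)F)nc1N1CCC(c2ccccc2)CC1)c1ccc(NS(C)(=O)=O)c(F)c1` keeps every atom and bond of compound 3; the only change is the two compounds have the same atoms and bonds; at least one stereo element is drawn with a configuration in one of them and without one in the other: 1 of 1 stereo elements differ; a stereocentre at a saturated chain carbon is drawn without a configuration in compound 3 and R in compound 4. Compound 3 is thus drawn as a mixture of both configurations at that carbon, compound 4 as one of them. Within the data shown here, none of the measured steps touches a stereocentre, since all three swap groups on an aromatic carbon, so they give no direct guide here. If the drawn configuration carries the activity of the mixture, a small decrease in the number is expected, close to the scatter; if it is the other one, a large increase. Weighing both, compound 4 is estimated at 0.5 nM, within 0.15 nM to 6 nM, which would mean a 1.2-fold lower number from compound 3 to compound 4 (0.08 log units; within the scatter).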

Compound 4, inhibition constant: 7.5 nM
The estimate for compound 4 lay 15-fold (1.18 log units) below the measured number; the measured number lies above the stated range.
By their numbers in this assay, from the lowest: compound 2; then compound 3; then compound 4; then compound 1.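

Until now, every measured step changed a group on an aromatic carbon, so nothing showed whether the saturated chain carbon carrying the stereocentre matters at all. In this assay, fixing that carbon as R is a sizeable change, a 13-fold higher number from compound 3 to compound 4 (1.10 log units; beyond the scatter), even though no atom or bond differs, so the three-dimensional arrangement at this one carbon clearly affects the reading, and the comparison rests on a single structural distinction: the fact that one of compounds 3 and 4 is drawn with a defined configuration and the other without, at the place where they differ. If compound 3 is indeed a mixture of both configurations, as it is drawn, then the R form cannot account for its strength, which points to the opposite configuration as the stronger partner, though that remains an inference from compound 3 and compound 4 alone.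

The S form itself is absent from the compounds shown, so how far it would read from compound 3 remains open, as does whether the same preference would hold with the dipropylamino group of compound 2 in place of 4-phenylpiperidin-1-yl. Also open, as far as these compounds go, is whether this carbon would tolerate an ethyl group, or a plain hydrogen that removes the stereocentre altogether, in place of its methyl group.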